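The compounds below may be only part of what the source reports. "The series", "measured", "known", "first", "only" and "open" are said of these compounds alone.

Compound 1 `CCCCCCCCn1cc(COC[C@@H]2OC[C@H](N)[C@@H]2O)nn1` gives 28100 nM in a functional assay on MCF7 cells (Homo sapiens) for antiproliferative activity, read by MTT assay, with a stated time of 48 h; a lower number here means a stronger inhibitor, a higher number a weaker inhibitor.
Compound 2 `CCCCCCCCCCCCn1cc(COC[C@@H]2OC[C@H](N)[C@@H]2O)nn1` gives 2210 nM in this assay.

Among the two numbers, compound 1 stands highest; its nearest neighbour is compound 2, reached by a 13-fold lower number from compound 1 to compound 2 (1.10 log units; beyond the scatter). That step is the only measured one, and it concerns a chain lengthened at the same place as the change now considered.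

Compound 3 `CCCCCCCCCCCCCCCCCCn1cc(COC[C@@H]2OC[C@H](N)[C@@H]2O)nn1` differs from compound 1 by decyl in place of hydrogen on a saturated chain carbon, eight bonds along the chain from an aromatic nitrogen. Going by the values given here, the one step that bears on it is a 13-fold lower number from compound 1 to compound 2 (1.10 log units; beyond the scatter), which was large and beyond the scatter. The change to compound 3 is a longer extension of the same kind, so a lower number in this assay is expected for compound 3, probably with a step at least as large as that seen for compound 2, though whether the gain continues at the same rate across the longer chain cannot be told from two compounds alone. Compound 3 is therefore expected to give about 700 nM, with a range of 120 nM to 4000 nM, which means an expected step of a 40-fold lower number from compound 1 to compound 3 (1.60 log units; beyond the scatter).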

Compound 3, half-maximal inhibitory concentration: 7580 nM
For compound 3 the middle estimate is 11-fold (1.03 log units) below the measured one; the whole stated range lies below it.
By their numbers in this assay, from the lowest: compound 2; then compound 3; then compound 1.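

With decyl in place of hydrogen on a saturated chain carbon, eight bonds along the chain from an aromatic nitrogen, this assay still shows a 3.7-fold lower number from compound 1 to compound 3 (0.57 log units; beyond the scatter) and so the longest chain keeps an advantage over the shortest, though a smaller one than a 13-fold lower number from compound 1 to compound 2 (1.10 log units; beyond the scatter) gave. Extending the chain further reverses the direction of the change, with a 3.4-fold higher number from compound 2 to compound 3 (0.54 log units; beyond the scatter) and this is what the first two compounds could not show: among these three compounds the number does not fall steadily with chain length, and compound 2 holds the lowest value, with compound 3 going against any simple trend towards longer chains. Nothing available accounts for this turn in the response to chain length.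

The three compounds leave open where between compound 2 and compound 3 the lowest number lies, and whether chains shorter than that of compound 1 continue the trend seen from compound 1 to compound 2. They also leave open how this position would respond to a chain ending in an amine or a carboxylic acid, or to a chain carrying a phenyl ring.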